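The source may report more compounds than this note shows. Statements on the series, on what has been measured and on what is new or still open speak of the compounds shown alone.

In a functional assay on NIH3T3 cells for agonist activity at Urotensin-2 receptor (Homo sapiens), with a stated time of 5 days (a higher number here means that more compound is needed for the effect, a lower number that less compound is needed), the measured compounds are:
Compound 1 `CN(C)CCC(NC(=O)/C=C/c1ccc(C(F)(F)F)cc1)c1ccc2ccccc2c1`: 135 nM
Compound 2 `COc1ccc(/C=C/C(=O)NC(CCN(C)C)c2ccc(Cl)cc2)cc1`: 513 nM

Of these two numbers compound 2 holds the higher one; compound 1 sits lower by a gap beyond the usual scatter. Compound 3 `CN(C)CCC(NC(=O)/C=C/c1ccc(C(F)(F)F)cc1)c1ccc(Cl)cc1` has not yet been measured in this assay. It differs from compound 2 in one place: trifluoromethyl in place of methoxy on an aromatic carbon. Among the measured compounds shown here, no single-change step between measured compounds is available to size this swap, and compound 1 differs from compound 2 in two places. Given that compound 1, which shares the trifluoromethyl group, gives 135 nM, a modest downward step is expected, estimated as a 2.1-fold lower number from compound 2 to compound 3 (0.31 log units; beyond the scatter). Compound 3 is expected at 250 nM, within 80 nM to 800 nM.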

Compound 3, half-maximal effective concentration: 129 nM
Compound 3: middle estimate off by 1.9-fold (0.29 log units), on the high side; measured number inside the range.
By their numbers in this assay, from the lowest: compounds 3 and 1 (each within the scatter of the next); then compound 2.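

In this assay, among the compounds shown here, trifluoromethyl in place of methoxy on the aromatic carbon gives a 4.0-fold lower number from compound 2 to compound 3 (0.60 log units; beyond the scatter) as the first size for this swap with the rest of the structure held constant. With trifluoromethyl in place, 4-chlorophenyl in place of naphthalen-2-yl gives a 1.0-fold lower number from compound 1 to compound 3 (0.02 log units; within the scatter) and so leaves the two groups indistinguishable here. No measurement at hand explains either step. Still open, going by these compounds, is how a nitrile on that aromatic carbon would compare with trifluoromethyl and methoxy, and whether the same swap would give a similar step on the naphthalen-2-yl compound.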